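From a hydroxypyridine arm to a bromomethoxyphenyl arm

This account rests on a few compounds, and the source may have more. Where it says the series, first, only, none or still open, it means among the compounds named here.

Within the data shown here, compound 3 `O=C1Nc2ccc(C(=O)c3ccco3)cc2/C1=C/c1ccc(O)nc1` has the highest of the three numbers measured so far. In an assay on HeLa cells for inhibition of Kinesin-like protein KIF15 (Homo sapiens), read by microscopy, with stated times of 2 s and 20 s, tested at 750 nM (on this read-out higher numbers stand for more inhibition at the one concentration tested (going by the name of the read-out) and lower numbers for less inhibition), compound 3 gives 26.5%. Among the measured compounds shown here, compound 1 `O=C1Nc2ccc(C(=O)c3ccco3)cc2/C1=C/c1cc(F)c(O)c(F)c1` gives 21%, and the only single-place step among the measured compounds, a number 5.5 percentage points higher from compound 1 to compound 3 (within the scatter), shows that exchanging one arm for another on the chain carbon can leave the read-out essentially unchanged. For the measured compounds named here, compound 2 `COc1c(Br)cc(/C=C2\C(=O)Nc3ccc(C(=O)c4ccco4)cc32)cc1Br` gives -12.6%, far below compound 3 and well beyond the scatter, although no single-place step joins those two compounds.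

The change to compound 4 `COc1ccc(/C=C2\C(=O)Nc3ccc(C(=O)c4ccco4)cc32)cc1Br` is 3-bromo-4-methoxyphenyl in place of 6-hydroxypyridin-3-yl on a double-bonded chain carbon bound to a double-bonded ring carbon. Going by the values given here, no measured step covers this exact exchange, so the one known step is only a loose guide. Compound 2 is the nearest relative of compound 4, carrying the same methoxy group and bromine on the phenyl ring together with one further bromine. Because compound 2 gives -12.6% where compound 3 gives 26.5%, a clear drop is expected for the new arm. The expected step is a number 26.5 percentage points lower from compound 3 to compound 4 (beyond the scatter). Compound 4 is therefore expected to give 0%, within a range from -20% to 20%.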

Compound 4, a percentage reported as inhibition, at one concentration (the size of the read-out at that concentration, not a potency): 2.3%
Beside the measured number, compound 4's estimate is 2.3 percentage points below it, within the range that was stated.
By their numbers in this assay, from the lowest: compound 2; then compound 4; then compounds 1 and 3 (each within the scatter of the next).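

In this assay, the chain carbon no longer looks indifferent to its arm: the earlier exchange of one hydroxy-bearing arm for another stayed within the scatter, whereas 3-bromo-4-methoxyphenyl gives a number 24.2 percentage points lower from compound 3 to compound 4 (beyond the scatter) and, against the 3,5-difluoro-4-hydroxyphenyl arm, a number 18.7 percentage points lower from compound 1 to compound 4 (beyond the scatter). The new compound also provides the first single-place view of the bromines on this arm, as hydrogen in place of bromo on an aromatic carbon gives a number 14.9 percentage points higher from compound 2 to compound 4 (beyond the scatter), so the added bromine goes with a lower number on this methoxyphenyl arm. Nothing independent accounts for either shift, and no outside measurement bears on these results.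

The compounds shown leave open whether the lower numbers follow the loss of the hydroxy group, the arrival of the methoxy group or the remaining bromine, as each arm exchange alters these together. Also open, as far as these compounds go, is how an arm carrying an amine or a carboxylic acid would read when placed on a double-bonded chain carbon bound to a double-bonded ring carbon.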